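The source may report more compounds than this note shows. Statements on the series, on what has been measured and on what is new or still open speak of the compounds shown alone.

Compound 1 `C[C@@H](NC1CCN(CCCc2c[nH]c3ccc(-n4cnnc4)cc23)CC1)c1ccccc1` carries, on a saturated ring carbon of the shared core, a (1-phenylethyl)amino group. Among the compounds with values here, in a functional assay on CHO cells for activation of 5-hydroxytryptamine receptor 1D (Homo sapiens), read by GTPgammaS binding (a lower number here means a smaller maximal response, a higher number a larger maximal response), compound 1 gives 90%, the highest of the two numbers so far; its nearest neighbour is compound 2 `CC(=O)Nc1ccc(CNC2CCN(CCCc3c[nH]c4ccc(-n5cnnc5)cc34)CC2)cc1`, which in this assay gives 75%. Within the data shown here, the one measured step between them, a number 15 percentage points lower from compound 1 to compound 2 (beyond the scatter), comes from exchanging the group on the amine nitrogen and lies beyond the scatter, though it remains modest.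

Compound 3 `c1ccc(CNCC2CCN(CCCc3c[nH]c4ccc(-n5cnnc5)cc34)CC2)cc1` keeps every atom of compound 1 but joins them differently: (benzylamino)methyl in place of (1-phenylethyl)amino on a saturated ring carbon. The nitrogen thus moves one bond further from the ring and the stereocentre disappears. Among the measured compounds shown here, no measured step mirrors this rearrangement; the step from compound 1 to compound 2 is the only guide, and it shows that a change at this amine can cost maximal response in this assay without abolishing it. A similar or somewhat smaller effect is therefore expected for compound 3, whose efficacy in this assay is estimated at 80%, within 60% to 100%, the expected change being a number 10 percentage points lower from compound 1 to compound 3 (within the scatter).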

Compound 3, largest response reached (reported as efficacy), in percent of the reference or control that the assay uses: 101%
The estimate for compound 3 lay 21 percentage points below the measured number; measured number above the stated range.
By their numbers in this assay, from the lowest: compound 2; then compound 1; then compound 3.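

In this assay, the step to (benzylamino)methyl is a number 11 percentage points higher from compound 1 to compound 3 (beyond the scatter), whereas the earlier exchange on the amine nitrogen was a number 15 percentage points lower from compound 1 to compound 2 (beyond the scatter), so changes at this position can move the maximal response in either direction. The rearrangement keeps the same heavy atoms and the same aromatic ring and removes the defined stereocentre, which shows that this stereocentre is not needed for a maximal response of this size. Nothing available here accounts for the rise in maximal response.

The two compounds differ both in the stereocentre and in how the amine nitrogen is joined to the saturated ring carbon, so the compounds shown cannot assign the rise to either change alone; a benzylamino group on that ring carbon, or a [(1-phenylethyl)amino]methyl group, would separate the two. On these data alone, it also remains open whether a 4-acetamidobenzyl group on the amine nitrogen of the (benzylamino)methyl arrangement, or a longer chain such as (2-phenylethylamino)methyl, would keep the response seen for compound 3.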